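The compounds below may be only part of what the source reports. "The series", "measured", "known", "first", "only" and "open" are said of these compounds alone.

Working notes on the series. In a functional assay on M14 cells (Homo sapiens) (on this read-out lower numbers stand for stronger inhibition of growth and higher numbers for weaker inhibition of growth), compound 1 `COc1cc(CSc2cc(Cl)c(-c3nnc(-c4ccc(Cl)cc4)s3)cc2S(=O)(=O)NC(=N)NO)cc(OC)c1OC` gives 40700 nM, the highest of the two numbers in hand; its nearest neighbour is compound 2 `N=C(NO)NS(=O)(=O)c1cc(-c2nnc(-c3ccc(Cl)cc3)s2)c(Cl)cc1SCc1ccccc1`, which in this assay gives 1680 nM. Within the data shown here, the only measured step, a 24-fold lower number from compound 1 to compound 2 (1.38 log units; beyond the scatter), concerns a change on the saturated chain carbon bound to a sulfur and leaves the heteroaryl part of the shared core untouched.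

Compound 3 `COc1cc(CSc2cc(Cl)c(-c3nc(-c4ccccc4)no3)cc2S(=O)(=O)NC(=N)NO)cc(OC)c1OC` is not yet measured in this assay. It differs from compound 1 by 3-phenyl-1,2,4-oxadiazol-5-yl in place of 5-(4-chlorophenyl)-1,3,4-thiadiazol-2-yl on an aromatic carbon. Among the measured compounds shown here, no measured step touches this part of the core, so the step from compound 1 to compound 2 gives no guide to its direction or size. With nothing in hand that bears on it, compound 3 is estimated to stay close to compound 1, with a wide margin either way, as a 1.4-fold lower number from compound 1 to compound 3 (0.13 log units; within the scatter). The estimate for compound 3 in this assay is therefore 30000 nM, within the range 5000 nM to 150000 nM.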

Compound 3, concentration for 50% growth inhibition: 6610 nM
For compound 3 the middle estimate is 4.5-fold (0.66 log units) above the measured one; measured number inside the range.
By their numbers in this assay, from the lowest: compound 2; then compound 3; then compound 1.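

In this assay the aromatic carbon para to a large group proves responsive as well, with a 6.2-fold lower number from compound 1 to compound 3 (0.79 log units; beyond the scatter), so the number moves at this part of the core while the 3,4,5-trimethoxyphenyl end stays fixed. The change is compound, since 3-phenyl-1,2,4-oxadiazol-5-yl replaces both the five-membered ring and the chlorinated phenyl of 5-(4-chlorophenyl)-1,3,4-thiadiazol-2-yl, although the hydrogen-bond donor and acceptor counts stay the same. Nothing in hand explains the shift.

Still open, going by these compounds, is which part of the change carries the step: a 3-(4-chlorophenyl)-1,2,4-oxadiazol-5-yl group at this place would separate the ring from the chlorine. Also open, on these data alone, is whether the same step holds when the plain phenyl of compound 2 sits on the chain carbon bound to sulfur.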